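Phenyl to phenoxy on a shared core

A few compounds are considered here, and "the series" means these few. Any claim that something is new, unique, unknown or untested is made for them only; others in the source may bear on it.

In a physicochemical assay for acid dissociation, compound 3 `COc1cccc(CNCCCNc2ccnc3cc(-c4ccccc4)ccc23)c1O` gives 9.47. Compound 2 `COc1cccc(CNCCCNc2ccnc3cc(CCC(C)C)ccc23)c1O` gives 9.47, level with compound 3 at the digits shown, and together these two are the highest of the three numbers. Compound 1 `COc1cccc(CNCCCNc2ccnc3cc(Oc4ccc(F)cc4)ccc23)c1O` gives 9.28, with a number 0.19 log units higher from compound 1 to compound 3 (within the scatter) and a number 0.19 log units higher from compound 1 to compound 2 (within the scatter) both sitting inside the scatter. Compound 4 `COc1cccc(CNCCCNc2ccnc3cc(Oc4ccccc4)ccc23)c1O` differs from compound 3 by phenoxy in place of phenyl on an aromatic carbon. The measured step that bears most on this change is a number 0.19 log units higher from compound 1 to compound 3 (within the scatter), which runs the other way, from a 4-fluorophenoxy to a phenyl, and was small. Compound 4 is therefore expected to land close to compound 3. The step of a number 0.15 log units lower from compound 3 to compound 4 (within the scatter) is expected to stay within the scatter. The estimate for compound 4 is 9.32, ranging from 9.05 to 9.6.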

Compound 4, acid dissociation constant: 9.28
Beside the measured number, compound 4's estimate is 0.04 log units above it, within the range that was stated.
By their numbers in this assay, from the lowest: compounds 1, 4, 2 and 3 (each within the scatter of the next).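

In this assay, phenoxy in place of phenyl gives a number 0.19 log units lower from compound 3 to compound 4 (within the scatter) and phenoxy in place of isopentyl gives a number 0.19 log units lower from compound 2 to compound 4 (within the scatter) so phenoxy, phenyl and isopentyl at this position all read alike. Hydrogen in place of fluoro gives no change at the digits printed from compound 1 to compound 4 (within the scatter) and this is the first step here that keeps the phenoxy group and changes only the fluoro. No measurement is available that would explain these readings. Still open, going by these compounds, is whether an amine or a carboxylic acid at this position would shift the number beyond the scatter.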